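Aryl swap at the thiophene end of the series

This account rests on a few compounds, and the source may have more. Where it says the series, first, only, none or still open, it means among the compounds named here.

Measured so far:
compound 1 `Cc1ccc(-c2cc3ncn([C@H]4CCN(C(=O)N(C)[C@H]5CCN(C)C5)C4)c(=O)c3s2)cc1` — 15 nM in an assay on isolated protein for binding affinity to melanin-concentrating hormone receptor 1 (Homo sapiens); on this read-out higher numbers stand for weaker inhibition and lower numbers for stronger inhibition
compound 2 `Cc1ccc(-c2cc3ncn([C@H]4CCN(C(=O)N(C)[C@H]5CCN(C6CCOCC6)C5)C4)c(=O)c3s2)cc1` — 14 nM in this assay

In this assay compound 2 gives the lowest of the two numbers, with compound 1 within the scatter of it: a 1.1-fold lower number from compound 1 to compound 2 (0.03 log units; within the scatter).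

Compound 3 `CN(C(=O)N1CC[C@H](n2cnc3cc(-c4ccc5c(c4)OCCO5)sc3c2=O)C1)[C@H]1CCN(C2CCOCC2)C1` changes a different part of the shared core: 2,3-dihydro-1,4-benzodioxin-6-yl in place of 4-methylphenyl on an aromatic carbon. Among the measured compounds shown here, no measured step touches this aromatic position, so the one step known, from compound 1 to compound 2 on the ring amine, gives no guide. Compound 3 is therefore expected near compound 2, a 1.4-fold higher number from compound 2 to compound 3 (0.15 log units; within the scatter), with a wide range.

Estimate for compound 3 in this assay: 20 nM, range 6 nM to 70 nM.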

Compound 3, inhibition constant: 45 nM
Estimate against measurement, compound 3: 2.3-fold (0.35 log units) below, within the range that was stated.
By their numbers in this assay, from the lowest: compounds 2 and 1 (each within the scatter of the next); then compound 3.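

The aromatic carbon next to the ring sulfur is sensitive to the aryl group in this assay: the change to 2,3-dihydro-1,4-benzodioxin-6-yl gives a 3.2-fold higher number from compound 2 to compound 3 (0.51 log units; beyond the scatter), whereas the ring-amine change gave a 1.1-fold lower number from compound 1 to compound 2 (0.03 log units; within the scatter). Replacing 4-methylphenyl here therefore moves the number more than that amine change did. Nothing measured explains this step.

Open, on these data alone, is whether the fused non-aromatic ring or its two oxygens matter, since neither has been separated from the other. A 4-methoxyphenyl or pyridinyl group at this carbon would test that.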